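The source may hold more compounds than are shown below. What is called first, only, known or untested is meant among the compounds shown, and "the series" means these compounds.

Working notes on the series. Compound 1 `CN(c1ccccc1)S(=O)(=O)C1CC2OC1C(c1ccc(NC(=O)CCCCCCC(=O)O)cc1)=C2c1ccc(O)cc1`, compound 2 `COc1cccc(N(C)S(=O)(=O)C2CC3OC2C(c2ccc(NC(=O)CCCCCCC(=O)O)cc2)=C3c2ccc(O)cc2)c1` and compound 3 `CN(c1ccccc1Cl)S(=O)(=O)C1CC2OC1C(c1ccc(NC(=O)CCCCCCC(=O)O)cc1)=C2c1ccc(O)cc1` share one core and differ only in the ring held on the sulfonamide nitrogen. In an ADME assay on Vero cells (Chlorocebus sabaeus) for antiproliferative activity, read by MTT assay, with a stated time of 72 h (a higher number here means a weaker inhibitor, a lower number a stronger inhibitor), compound 1 gives a limit only, > 100000 nM. In this assay compound 2 also reaches no number but a limit, > 100000 nM. Compound 3 likewise returns a limit, > 100000 nM. The steps a step that the two limits leave unreadable from compound 1 to compound 2, a step that the two limits leave unreadable from compound 1 to compound 3 and a step that the two limits leave unreadable from compound 2 to compound 3 cannot be sized, since all three values sit at the limit of > 100000 nM in this assay, at which 3 of the 3 values shown sit. Compound 2 therefore stands at the limit of this assay, with no measured number to place it against the others.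

Compound 4 `CCN(c1cccc(C)c1)S(=O)(=O)C1CC2OC1C(c1ccc(NC(=O)CCCCCCC(=O)O)cc1)=C2c1ccc(O)cc1` differs from compound 2 by the change (ethyl(3-methylphenyl)amino in place of (3-methoxyphenyl)(methyl)amino on a sulfonyl sulfur). Going by the values given here, none of the measured steps covers this particular exchange; the nearest, a step that the two limits leave unreadable from compound 2 to compound 3, swaps the aryl ring on that nitrogen and is itself unreadable. Among the compounds with values here, with every compound measured so far resting at the limit, no direction can be read, and the step that the limit leaves unreadable from compound 2 to compound 4 is expected to show nothing beyond the scatter, most likely another limit. Compound 4 is accordingly estimated at 200000 nM, with a range from 60000 nM to 1000000 nM.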

Compound 4, half-maximal inhibitory concentration: > 100000 nM
Compound 4 was reported as a limit; the forecaster's own chance of this, stated with the estimate: 85%; the middle value is on the limit's open side.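

The steps from compound 1, compound 2 and compound 3 to compound 4 cannot be read, because all four results are limits and not numbers: the limit of > 100000 nM in this assay, at which 4 of the 4 values shown sit.

The compounds shown leave open whether any group on the sulfonamide nitrogen of the shared core would give a measured number in this assay.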